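Acetyl to methoxycarbonyl on the shared core

The source may report more compounds than this note shows. Statements on the series, on what has been measured and on what is new or still open speak of the compounds shown alone.

Measured in a functional assay on NCI-H727 cells (Homo sapiens) for antiproliferative activity, with a stated time of 48 h; a higher number here means a weaker inhibitor, a lower number a stronger inhibitor:
- compound 1 `CCN(CC)c1ccc(-c2ccc(C#N)cc2)nn1`: > 25000 nM (a limit)
- compound 2 `CCN(CC)c1ccc(-c2ccc(C(C)=O)cc2)nn1`: 25000 nM

Among the compounds with values here, compound 2, at 25000 nM, holds the only actual number so far. Compound 3 `CCN(CC)c1ccc(-c2ccc(C(=O)OC)cc2)nn1` differs from it by methoxy in place of methyl on a carbonyl carbon. Within the data shown here, the sole measured step, a number no higher from compound 1 to compound 2 (the limit leaves the size open), has no readable size because of the limit of > 25000 nM in this assay, at which 1 of the 2 values shown sits, and it concerns a different change. The estimated step is no change at the digits printed from compound 2 to compound 3 (within the scatter), expected to stay within the scatter, with no direction favoured. For compound 3 the estimated value is 25000 nM, with an expected range of 12000 nM to 45000 nM.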

Compound 3, half-maximal inhibitory concentration: 90 nM
The estimate for compound 3 lay 280-fold (2.44 log units) above the measured number, outside the stated range (below it).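

In this assay the shared core shows a 280-fold lower number from compound 2 to compound 3 (2.44 log units; beyond the scatter) when acetyl gives way to methoxycarbonyl, so this position is far from indifferent to the group it carries. Acetyl and methoxycarbonyl are not interchangeable here, even though they differ in one place only. Against the cyano group the change gives an at least 270-fold lower number from compound 1 to compound 3 (2.44 log units; beyond the scatter) and that size is only a bound: the limit of > 25000 nM in this assay, at which 1 of the 3 values shown sits.

Going by these compounds, how a carboxylic acid, a primary amide or ethoxycarbonyl would behave on this carbonyl carbon stays open.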